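Working notes: the step to compound 3

The source may hold more compounds than are shown below. What is called first, only, known or untested is meant among the compounds shown, and "the series" means these compounds.

Compound 1 `CC(C)=CC(=O)Nc1cccc(Oc2nc(Nc3ccn(C)n3)nc3c2CSCC3)c1`: > 50000 nM
Compound 2 `CC(C)/C=C/C(=O)Nc1cccc(Oc2nc(Nc3ccn(C)n3)nc3c2CSCC3)c1`: > 50000 nM

Both entries are limits, not numbers, and both come from a functional assay on MCF7 cells (Homo sapiens) for antiproliferative activity, read by MTT assay, with a stated time of 72 h; a lower number here means a stronger inhibitor, a higher number a weaker inhibitor. Among the measured compounds shown here, the series so far offers only (the limit of > 50000 nM in this assay, at which 2 of the 2 values shown sit). Compound 2 stands at > 50000 nM, which is a limit. For the measured compounds named here, the one measured step is a step that the two limits leave unreadable from compound 1 to compound 2. It lies at the amide end and gives no size to carry over.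

Compound 3 `COc1cccc(Nc2nc3c(c(Oc4cccc(NC(=O)/C=C/C(C)C)c4)n2)CSCC3)c1` changes a different place: 3-methoxyphenyl in place of 1-methyl-1H-pyrazol-3-yl on a nitrogen on an aromatic ring. Going by the values given here, no measured step covers this replacement, so the data fix neither size nor direction. Any readable value in this assay would lie on the stronger side of the limit, so a small shift that way is expected, though another limit is about as likely. The expected step is an at least 1.2-fold lower number from compound 2 to compound 3 (0.09 log units; that floor lies within the scatter). For compound 3 the estimated value is 40000 nM, with an expected range of 12000 nM to 100000 nM.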

Compound 3, half-maximal inhibitory concentration: 21800 nM
The estimate for compound 3 lay 1.8-fold (0.26 log units) above the measured number; the range from low to high includes it.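

In this assay, among the compounds shown here, compound 3 is the first entry to read as a number rather than a limit, which marks the group on this nitrogen as a place where the read-out can move: the limit of > 50000 nM in this assay, at which 2 of the 3 values shown sit. Putting 3-methoxyphenyl in place of 1-methyl-1H-pyrazol-3-yl gives an at least 2.2-fold lower number from compound 2 to compound 3 (0.36 log units; beyond the scatter), a floor on the size of the step rather than its full size. For the compounds shown here, the earlier step at the amide end cannot be read, so this is the first change with a direction.

The compounds shown do not separate the phenyl ring from its methoxy group, so an unsubstituted phenyl or a 3-hydroxyphenyl on this nitrogen would be the informative comparison. As far as these compounds go, whether the amide end matters once 3-methoxyphenyl is in place also stays open, for instance with 2-methylprop-1-en-1-yl on the carbonyl carbon.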